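A few compounds are considered here, and "the series" means these few. Any claim that something is new, unique, unknown or untested is made for them only; others in the source may bear on it.

Measured so far:
- compound 1 `COc1ccc([C@@H]2C/C(=N/OCc3cn(-c4ccccc4CO)nn3)c3cc(CC=C(C)C)c(OC)cc3O2)cc1`: 100%
- compound 2 `C#CCO/N=C1/C[C@@H](c2ccc(OC)cc2)Oc2cc(OC)c(CC=C(C)C)cc21`: 41%

In a functional assay on PC-3 cells (Homo sapiens) for inhibition, read by sulforhodamine B assay, with a stated time of 48 h, tested at 50 uM (on this read-out higher numbers stand for more inhibition of growth at the one concentration tested and lower numbers for less inhibition of growth), compound 1 gives 100%, the higher of the two numbers in hand. Compound 2, which carries a propargyl ether on the oxime instead of the triazole-linked arm, gives 41%, a gap beyond the scatter, so the arm on the oxime is where the two measured values differ. For the measured compounds named here, no step between measured compounds that differ in one place is available.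

Compound 3 `COc1ccc([C@@H]2C/C(=N/OCc3cn(-c4ccc(C#N)cc4)nn3)c3cc(CC=C(C)C)c(OC)cc3O2)cc1` keeps the shared core of compound 1 and differs only in the arm: 4-cyanophenyl in place of 2-(hydroxymethyl)phenyl on an aromatic nitrogen. Going by the values given here, with no measured pair of this kind, the size of the step is uncertain; the expected change is a modest fall, a number 15 percentage points lower from compound 1 to compound 3 (beyond the scatter), which may still lie within the scatter, because compound 1 already gives 100% in this assay. Compound 3 is expected to give about 85%, in a range of 55% to 100%.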

Compound 3, percent growth inhibition at one concentration: 50%
The estimate for compound 3 lay 35 percentage points above the measured number, outside the stated range (below it).
By their numbers in this assay, from the lowest: compounds 2 and 3 (each within the scatter of the next); then compound 1.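

With the five-membered aromatic ring with 3 nitrogen kept, exchanging only the group on its aromatic nitrogen gives, in this assay, a number 50 percentage points lower from compound 1 to compound 3 (beyond the scatter). For the compounds shown here, this is the first single-place step: it shows that this position alone can carry a large change, and that the arm's ring does not by itself secure the value of compound 1. The exchange replaces 2-(hydroxymethyl)phenyl, with 1 hydrogen-bond donor, by 4-cyanophenyl, with 0 hydrogen-bond donors, but nothing available explains the step.

The compounds shown do not separate loss of the hydroxymethyl from arrival of the nitrile, or the effect of the group from that of its place on the phenyl ring. Unsubstituted phenyl and 4-(hydroxymethyl)phenyl at this position would address these open points.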